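Swapping a Thiophene Amide for an Ether Amide

The source may hold more compounds than are shown below. What is called first, only, known or untested is meant among the compounds shown, and "the series" means these compounds.

Compound 1 `CN(C)c1cc2[nH]c(C3CCCCC3)nc2cc1NC(=O)c1cccs1` is one of three measured compounds built on a shared core. In an ADME assay on Vero cells (Chlorocebus sabaeus) for cytotoxicity, read by resazurin assay, with a stated time of 3 days (on this read-out higher numbers stand for weaker inhibition and lower numbers for stronger inhibition), compound 1 reaches only the limit > 100 ug/mL, so no number stands for it. Compound 2 `COCCOC(=O)Nc1cc2nc(C3CCCCC3)[nH]c2cc1N1CCCC1` also sits at a limit in this assay, > 100 ug/mL. Compound 3 `CCCCOC(=O)Nc1cc2nc(C3CCCCC3)[nH]c2cc1N(C)CCN(C)C` likewise gives a limit in this assay, > 100 ug/mL. All three values thus share (the limit of > 100 ug/mL in this assay, at which 3 of the 3 values shown sit). Compound 4 `CCCOCC(=O)Nc1cc2nc(C3CCCCC3)[nH]c2cc1N(C)C` differs from compound 1 by propoxymethyl in place of thiophen-2-yl on a carbonyl carbon. Going by the values given here, no measured pair differs in one place, so no step can be read directly. Because the limit of > 100 ug/mL in this assay, at which 3 of the 3 values shown sit, holds for every compound shown, the expected step is a step that the limit leaves unreadable from compound 1 to compound 4, none beyond the usual scatter. Compound 4 is therefore estimated at 150 ug/mL, most likely again as a limit, between 80 ug/mL and 300 ug/mL.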

Compound 4, half-maximal inhibitory concentration: < 50 ug/mL
Compound 4: no number, only a limit (the forecaster's own chance of this, stated with the estimate: 85%); middle value at least 3.0-fold (0.47 log units) away from the limit.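

Compound 4 is the first compound shown whose limit in this assay lies on the low side: < 50 ug/mL. Propoxymethyl in place of thiophen-2-yl on a carbonyl carbon gives an at least 2.0-fold lower number from compound 1 to compound 4 (0.30 log units; that floor lies within the scatter), so this change yields a readable step even though both ends are limits. Going by these compounds, the true size of the step remains unknown.

The compounds shown leave open what number compound 4 would reach, and whether any shift follows the loss of the ring or the arrival of the ether oxygen. A plain pentyl chain on the same carbonyl carbon would separate these two.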